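The compounds below may be only part of what the source reports. "The series", "measured", "known", "first", "only" and "open" are said of these compounds alone.

Compound 2 `O=C(O)CCCCCCN1C(=O)CC[C@@H]1CC[C@@H](O)CCc1ccccc1` is the starting point. In an assay on HEK293 cells for binding affinity to prostaglandin E2 receptor EP2 subtype (Rattus norvegicus) (on this read-out higher numbers stand for weaker inhibition and lower numbers for stronger inhibition), compound 2 gives > 3200 nM, which is a limit of the assay rather than a number. Compound 1 `O=C(O)CCCCCCN1C(=O)CCC1CCC(O)CCc1ccccc1` has the same atoms and bonds, drawn without configurations; in this assay compound 1 also gives only a limit, > 3200 nM. The step that the two limits leave unreadable from compound 1 to compound 2 cannot be read because the limit of > 3200 nM in this assay, at which 2 of the 3 values shown sit, leaves both ends open, and because the fact that one of compounds 1 and 2 is drawn with a defined configuration and the other without, at the place where they differ adds nothing that a limit could resolve. Going by the values given here, the third known compound, compound 3 `O=C(O)c1ccc(CCCN2C(=O)CC[C@@H]2CCC(O)Cc2cccc(-c3ccccc3)c2)s1`, gives 135 nM in this assay, a number rather than a limit; no single-place step joins it to compound 2.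

Compound 4 `N#Cc1cccc(C[C@H](O)CC[C@H]2CCC(=O)N2CCCCCCC(=O)O)c1` is not yet measured. It differs from compound 2 by 3-cyanophenyl in place of benzyl on a saturated chain carbon, two bonds along the chain from an oxygen on a saturated carbon. Among the compounds with values here, the only measured step touching compound 2 is the unreadable one from compound 1, so no direction is indicated. The expectation for compound 4 is a step of an at least 1.0-fold lower number from compound 2 to compound 4 (0.02 log units; that floor lies within the scatter) of uncertain sign and wide spread. The estimated value for compound 4 is 3000 nM, between 400 nM and 20000 nM.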

Compound 4, half-maximal inhibitory concentration: > 3200 nM
Compound 4 ended at the assay's limit (the forecaster's own chance of this, stated with the estimate: 60%); middle value at least 1.0-fold (0.02 log units) away from the limit.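

Going by these compounds alone, no step from compound 2 to compound 4 can be read: both compounds end at a limit of this assay, not at a number. The compounds shown leave open whether 3-cyanophenyl in place of benzyl shifts the value at all, and in which direction.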